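Swapping One Aryl Group: From Compound 2 to Compound 3

The source may hold more compounds than are shown below. What is called first, only, known or untested is meant among the compounds shown, and "the series" means these compounds.

Compound 1, `O=C(/C=C\Nc1ccc(Cl)cc1)c1cn(-c2ccccc2)nc1-c1ccc(F)cc1`, in a functional assay on PC-3 cells (Homo sapiens) for antiproliferative activity, read by MTT assay, with a stated time of 48 h (on this read-out lower numbers stand for stronger inhibition and higher numbers for weaker inhibition), gives 3800 nM.
Compound 2, `COc1ccc(N/C=C\C(=O)c2cn(-c3ccccc3)nc2-c2ccc(F)cc2)cc1`, in this assay gives 4600 nM.

For the measured compounds named here, only two compounds have been measured, and their numbers sit close together. The step of a 1.2-fold higher number from compound 1 to compound 2 (0.08 log units; within the scatter) shows that exchanging these two groups on the aniline side barely moves the read-out. Compound 2 therefore stands at the higher of the two numbers, but its gap to compound 1 is within the scatter, so no order between them can be claimed.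

Compound 3, `COc1ccc(N/C=C\C(=O)c2cn(-c3ccccc3)nc2-c2cc(OC)c(OC)c(OC)c2)cc1`, is not yet measured. It differs from compound 2 in this way: 3,4,5-trimethoxyphenyl in place of 4-fluorophenyl on an aromatic carbon. Going by the values given here, this change sits on the shared core, at a place no measured step touches; the one known step, from compound 1 to compound 2, alters a different part of the molecule. Among the compounds with values here, there is thus no measured precedent for the size or direction of this change, and the expectation rests on a wide range.

Compound 3 is expected to give 2500 nM, with a likely range from 400 nM to 15000 nM. The expected step is a 1.8-fold lower number from compound 2 to compound 3 (0.26 log units; within the scatter), which is an estimate rather than a measurement.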

Compound 3, half-maximal inhibitory concentration: 9600 nM
The estimate for compound 3 lay 3.8-fold (0.58 log units) below the measured number, and the stated range covers the measured number.
By their numbers in this assay, from the lowest: compounds 1 and 2 (each within the scatter of the next); then compound 3.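

In this assay, for the compounds shown here, this is the first measured change on the aromatic carbon of the five-membered aromatic ring with 2 nitrogen, and it gives a 2.1-fold higher number from compound 2 to compound 3 (0.32 log units; beyond the scatter) as a modest rise. Going by these compounds alone, the number at this position therefore responds to the group it carries: with 3,4,5-trimethoxyphenyl in place of 4-fluorophenyl, inhibition is weaker by a small margin beyond the scatter, whereas the only earlier step, a 1.2-fold higher number from compound 1 to compound 2 (0.08 log units; within the scatter) on the aniline side, could not be told apart from noise. Nothing available gives a reason for this shift, so the result stands as an observation only.

On these data alone, with just these two groups at this position, it remains open whether a plain phenyl, a phenyl carrying a single methoxy, or a phenyl carrying an amine would give a number closer to that of compound 2 or to that of compound 3. As far as these compounds go, it is also open whether the same exchange would give a step of similar size and direction with the chloro group of compound 1 on the aniline side.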